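The source may report more compounds than this note shows. Statements on the series, on what has been measured and on what is new or still open speak of the compounds shown alone.

Two compounds of the series carry a measurement in a functional assay on the whole organism with Mus musculus as the target, with a stated time of 1 h, at a dose of 100 mg/kg by the intraperitoneal route; on this read-out lower numbers stand for less inhibition and higher numbers for more inhibition at the one dose given (going by the name of the read-out). Compound 1 `Fc1cccc(COc2nc3ccccc3s2)c1` gives 86.8% in this assay; compound 2 `Fc1ccc(COc2nc3ccccc3s2)cc1` gives 90.7%. Compound 1 holds the lower of the two numbers, yet the gap to compound 2 lies within the scatter, so the pair reads as level. Compound 3 `Clc1cccc(COc2nc3ccccc3s2)c1` is not yet measured; it differs from compound 1 by chloro in place of fluoro on an aromatic carbon. Going by the values given here, no measured step of this kind exists, so the step of a number 1.8 percentage points lower from compound 1 to compound 3 (within the scatter) is expected to stay within the scatter, with no clear direction. Compound 3 is estimated at 85% in this assay, with a range from 70% to 96%.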

Compound 3, a percentage reported as inhibition, in the whole organism at one dose (the size of the read-out at that dose, not a potency): 80%
For compound 3 the middle estimate is 5 percentage points above the measured one, and the stated range covers the measured number.
By their numbers in this assay, from the lowest: compounds 3, 1 and 2 (each within the scatter of the next, the first and the last beyond it).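

In this assay the exchange of chloro for fluoro on an aromatic carbon, meta to a large group, reads as a number 6.8 percentage points lower from compound 1 to compound 3 (within the scatter). Going by these compounds alone, this is the only single-place step so far, and it shows that compound 3 stays level with compound 1 at the one dose given. No measurement on hand accounts for this step.

From the compounds shown here alone, whether a methoxy group, an amine or a carboxylic acid in this place would move the read-out beyond the scatter remains open. So does whether chloro would read the same in the place fluoro holds in compound 2.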